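Benzyl amide in place of hydrazide on a cytotoxicity read-out

The source may hold more compounds than are shown below. What is called first, only, known or untested is meant among the compounds shown, and "the series" means these compounds.

Of the compounds shown here, three sharing one core have been measured in an ADME assay on RAW264.7 cells (Mus musculus) for cytotoxicity, with a stated time of 24 h; a lower number here means a stronger inhibitor, a higher number a weaker inhibitor. Compound 1 `CC(C)c1ccc(-c2cc(-c3ccc4c(c3)CCCC4)nc(Cl)c2C#N)cc1` carries a chloro group on the core and gives 8400 nM in this assay. Compound 2 `CCOC(=O)COc1nc(-c2ccc3c(c2)CCCC3)cc(-c2ccc(C(C)C)cc2)c1C#N` gives only a limit in this assay, > 50000 nM, meaning no number was obtained there (the limit of > 50000 nM in this assay, at which 1 of the 3 values shown sits). Compound 3 `CC(C)c1ccc(-c2cc(-c3ccc4c(c3)CCCC4)nc(OCC(=O)NN)c2C#N)cc1` gives 27700 nM, which is the highest of the two numbers shown, with compound 1 the nearer neighbour. The steps measured so far are an at least 5.9-fold higher number from compound 1 to compound 2 (0.77 log units; beyond the scatter), a 3.3-fold higher number from compound 1 to compound 3 (0.52 log units; beyond the scatter) and an at least 1.8-fold lower number from compound 2 to compound 3 (0.25 log units; that floor lies within the scatter).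

Compound 4 `CC(C)c1ccc(-c2cc(-c3ccc4c(c3)CCCC4)nc(OCC(=O)NCc3ccccc3)c2C#N)cc1` has not yet been measured. The change from compound 3 is benzyl in place of amino on an amide-type nitrogen. Among the measured steps, the one from compound 2 to compound 3 is the closest comparison, as it also alters the group on the carbonyl side of the core, and it stayed within the scatter; the two steps from compound 1 were modest in size. On that basis, the expected step of a 1.1-fold higher number from compound 3 to compound 4 (0.03 log units; within the scatter) in this assay is small, with no clear direction beyond the scatter. Compound 4 is therefore estimated at 30000 nM in this assay, with a likely range from 9000 nM to 100000 nM.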

Compound 4, half-maximal inhibitory concentration: 9900 nM
Beside the measured number, compound 4's estimate is 3.0-fold (0.48 log units) above it, and the stated range covers the measured number.
By their numbers in this assay, from the lowest: compounds 1 and 4 (each within the scatter of the next); then compound 3. At a limit, above all of these: compound 2.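

On the amide-type nitrogen, the group clearly counts in this assay: benzyl in place of amino gives a 2.8-fold lower number from compound 3 to compound 4 (0.45 log units; beyond the scatter), a step beyond the scatter at a site where the earlier change on the carbonyl carbon showed none that could be claimed. The result also qualifies what the first three compounds suggested, that replacing chloro on the aromatic carbon raises the number: compound 4 goes against this, since (benzylcarbamoyl)methoxy in place of chloro gives a 1.2-fold higher number from compound 1 to compound 4 (0.07 log units; within the scatter), within the scatter, so a long group at this place need not move the number at all. The remaining new step is an at least 5.0-fold lower number from compound 2 to compound 4 (0.70 log units; beyond the scatter), with a floor beyond the scatter, though this step starts from a limit and not from a number: the limit of > 50000 nM in this assay, at which 1 of the 4 values shown sits.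

As far as these compounds go, whether the aromatic ring of the benzyl group is what counts stays open, and a methyl or cyclohexylmethyl group on the same nitrogen would help to separate the ring from the added carbons. A carboxylic acid in place of the ester, or a longer chain between the carbonyl and the ring, is also absent from the compounds shown.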